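This account rests on a few compounds, and the source may have more. Where it says the series, first, only, none or still open, it means among the compounds named here.

Compound 1 `Cc1ccc(C(=O)Nc2ncc(Cc3ccc(F)cc3)s2)cc1`: "not toxic" (no number reported) in an ADME assay on HepG2 2.2.15 cells (Homo sapiens) for cytotoxicity; a higher number here means that more compound is tolerated, a lower number that less compound is tolerated.
Compound 2 `O=C(CCCCC(=O)Nc1ncc(Cc2ccc(F)cc2)s1)Nc1ncc(Cc2ccc(F)cc2)s1`: > 50000 nM, a limit of the assay.
Compound 3 `CCCCCC(=O)Nc1ncc(C(Oc2ccc3cc(Br)ccc3c2)c2ccc(Cl)cc2)s1`: > 50000 nM, also a limit of the assay.

Compound 3 thus stands where most of the measured compounds sit, at the limit of > 50000 nM in this assay, at which 2 of the 3 values shown sit, so no number is known for it, only that it is tolerated up to the limit. Compound 4 `O=S(=O)(Nc1ncc(C(Oc2ccc3cc(Br)ccc3c2)c2ccc(Cl)cc2)s1)c1ccc(Cl)cc1` has not yet been measured. It differs from compound 3 in one place: (4-chlorophenyl)sulfonyl in place of pentylcarbonyl on a nitrogen on an aromatic ring. Among the measured compounds shown here, no measured pair shows what this kind of change does in this assay, so there is nothing to lean on beyond the limits themselves. The step from compound 3 to compound 4 is expected to be an at least 1.2-fold lower number from compound 3 to compound 4 (0.09 log units; that floor lies within the scatter), none beyond the scatter. Compound 4 is therefore expected to give about 40000 nM, between 15000 nM and 100000 nM.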

Compound 4, half-maximal cytotoxic concentration: "not toxic" (no number reported)
No number was reported for compound 4; there is nothing to compare the estimate with.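

Compound 4 is reported only as "not toxic", so no step can be read from compound 3 to compound 4. Compound 3 remains a limit, not a number: the limit of > 50000 nM in this assay, at which 2 of the 4 values shown sit.

What replacing pentylcarbonyl with (4-chlorophenyl)sulfonyl does in this assay stays open, as does the concentration at which any of these compounds becomes toxic.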